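This account rests on a few compounds, and the source may have more. Where it says the series, first, only, none or still open, it means among the compounds named here.

Measured compounds:
compound 1 `CCCCCCCCc1ccc(OCC(=O)Cn2nnc(C)n2)cc1` — 27 nM
compound 2 `CCCCCCCCc1ccc(OCC(=O)Cn2nnc(-c3cccnc3)n2)cc1` — 23 nM

In an assay on microsomes from brain for inhibition of Fatty-acid amide hydrolase 1 (Rattus norvegicus), read by fluorescence and HPLC, with a stated time of 60 min (a higher number here means a weaker inhibitor, a lower number a stronger inhibitor), compound 2 gives 23 nM, the lowest of the two numbers, with compound 1 nearest. Within the data shown here, the only measured step is a 1.2-fold lower number from compound 1 to compound 2 (0.07 log units; within the scatter), which changes the substituent at the same aromatic carbon of the shared core and does not move the number beyond the scatter.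

Compound 3 `CCCCCCCCc1ccc(OCC(=O)Cn2nnc(Cc3ccccc3)n2)cc1` carries benzyl in place of pyridin-3-yl on an aromatic carbon. Among the measured compounds shown here, no measured step involves a benzyl group, so the single step that bears on this position, a 1.2-fold lower number from compound 1 to compound 2 (0.07 log units; within the scatter), is indirect evidence only: two different substituents at this carbon gave numbers within the scatter of each other. On that basis no step beyond the scatter is expected for compound 3 in this assay. The step from compound 2 to compound 3 is estimated at a 1.1-fold higher number from compound 2 to compound 3 (0.04 log units; within the scatter). Compound 3 is estimated at 25 nM, within a range of 10 nM to 70 nM.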

Compound 3, half-maximal inhibitory concentration: 66 nM
Compound 3: the middle estimate sits 2.6-fold (0.42 log units) below what was measured, within the range that was stated.
By their numbers in this assay, from the lowest: compounds 2 and 1 (each within the scatter of the next); then compound 3.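

In this assay, this aromatic carbon no longer looks indifferent to its substituent: benzyl in place of pyridin-3-yl gives a 2.9-fold higher number from compound 2 to compound 3 (0.46 log units; beyond the scatter), a modest step beyond the scatter, whereas methyl and pyridin-3-yl had stayed within the scatter of each other. Phenyl in place of hydrogen on the saturated chain carbon bound to this aromatic carbon gives a 2.4-fold higher number from compound 1 to compound 3 (0.39 log units; beyond the scatter), also modest and beyond the scatter, so the two steps to compound 3 point the same way. No supporting measurement accounts for this rise.

The compounds shown leave open whether the rise follows the saturated carbon that benzyl brings or the ring of carbon only, which directly attached phenyl and pyridin-3-ylmethyl would help separate. They also leave open how an amine or a carboxylic acid on this carbon would read.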